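The source may hold more compounds than are shown below. What is called first, only, known or untested is meant among the compounds shown, and "the series" means these compounds.

The account follows a single change on a shared core carried by two compounds from one study. Among the measured compounds shown here, compound 1, `Cc1cc(-c2cccc(O)c2)c2ncc(CSCCc3ccccc3)n2c1`, is the only compound for which an ADME assay on HEL cells (Homo sapiens) for cytotoxicity, with a stated time of 3 days (on this read-out higher numbers stand for lower toxicity in this test and lower numbers for higher toxicity in this test), yields a number at all: in this assay compound 1 gives 20 ug/mL. Compound 2, `Cc1cc(I)cn2c(CSCCc3ccccc3)cnc12`, reaches only a limit of this assay, and in this assay compound 2 is reported as >= 0.8 ug/mL. Among the values shown, then, compound 1 stands as the sole numerical read-out, with the other value being (the limit of >= 0.8 ug/mL in this assay, at which 1 of the 2 values shown sits).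

Compound 3, `COc1ccc(-c2cc(C)cn3c(CSCCc4ccccc4)cnc23)cc1`, has not yet been measured in this assay. It differs from compound 1 at one place: 4-methoxyphenyl in place of 3-hydroxyphenyl on an aromatic carbon. For the measured compounds named here, no measured pair in the set shares this change, so the effect of putting the 4-methoxyphenyl group where the 3-hydroxyphenyl group stood cannot be read from the numbers, and compound 2 offers no guidance since its value is a limit. The writer therefore expects a step from compound 1 to compound 3 of no change at the digits printed from compound 1 to compound 3 (within the scatter), that is, none beyond the usual scatter. The estimate for compound 3 in this assay is 20 ug/mL, expected to lie between 5 ug/mL and 80 ug/mL.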

Compound 3, minimum cytotoxic concentration: 20 ug/mL
Compound 3: the middle estimate sits on the measured number at the digits printed, within the range that was stated.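

In this assay, among the compounds shown here, the first step at this position that can be read is no change at the digits printed from compound 1 to compound 3 (within the scatter), with 4-methoxyphenyl in place of 3-hydroxyphenyl on the aromatic carbon. The entering group carries 0 hydrogen-bond donors and 8 heavy atoms, the leaving group 1 hydrogen-bond donor and 7 heavy atoms, and across this pair these differences come with no shift in the read-out beyond the scatter. Compound 2 stays a limit and not a number, so no step that involves it can be read: the limit of >= 0.8 ug/mL in this assay, at which 1 of the 3 values shown sits.

For the compounds shown here, the single pair changes two things at once, the group on the phenyl ring and the place it holds there, so a 3-methoxyphenyl or a 4-hydroxyphenyl group would be needed to tell these apart. On these data alone, whether the read-out would stay level with something other than a substituted phenyl ring on this aromatic carbon, such as an amine or a carboxylic acid, remains open, and so does whether a change in the phenethyl thioether chain on the other side of the shared core would leave it level.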